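A few compounds are considered here, and "the series" means these few. Any claim that something is new, unique, unknown or untested is made for them only; others in the source may bear on it.

Three compounds share one core and differ only in the group on a single aromatic carbon. Compound 1 `CCCCCNc1nc(N)c2nc(O)n(Cc3ccccc3)c2n1` carries pentylamino there; in a functional assay (spleen, spleen) for activation, with Mus musculus as the target (a higher number here means that more compound is needed for the effect, a lower number that less compound is needed), compound 1 gives 0.1 uM. Compound 2 `CCCCCOc1nc(N)c2nc(O)n(Cc3ccccc3)c2n1` carries pentyloxy, and compound 2 gives 0.01 uM. Compound 3 `CSc1nc(N)c2nc(O)n(Cc3ccccc3)c2n1` carries methylsulfanyl, and compound 3 gives 0.1 uM. Compound 3 thus stands level with compound 1, the two together at the highest numbers of the three, and a 10-fold higher number from compound 2 to compound 3 (1.00 log units; beyond the scatter).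

The next compound, compound 4 `CCCNc1nc(N)c2nc(O)n(Cc3ccccc3)c2n1`, makes one change from compound 3: propylamino in place of methylsulfanyl on an aromatic carbon. Among the compounds with values here, the step that bears on this is the one in which no change at the digits printed from compound 1 to compound 3 (within the scatter), an exchange of pentylamino for methylsulfanyl that is here run in the opposite direction, except that the group entering is propylamino rather than pentylamino. Within the data shown here, no measured step shows what shortening the chain does. Compound 4 is therefore expected to move by about no change at the digits printed from compound 3 to compound 4 (within the scatter), nothing beyond the scatter. Compound 4 is estimated at 0.1 uM, within a range from 0.03 uM to 0.5 uM.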

Compound 4, minimum effective concentration: 0.1 uM
Compound 4: the middle estimate sits on the measured number at the digits printed; measured number inside the range.
By their numbers in this assay, from the lowest: compound 2; then compounds 1, 3 and 4 (each within the scatter of the next).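

In this assay, the pentylamino chain can lose its ethyl end with no visible effect, as no change at the digits printed from compound 1 to compound 4 (within the scatter) shows, so this amino chain length does not separate compound 1 from compound 4. Propylamino and methylsulfanyl also read alike, with no change at the digits printed from compound 3 to compound 4 (within the scatter) in this assay, while pentyloxy keeps its lead over a second amino chain, with a 10-fold higher number from compound 2 to compound 4 (1.00 log units; beyond the scatter) setting compound 2 apart from all three others. Nothing measured here gives a reason for this pattern.

Still open, as far as these compounds go, is whether the advantage belongs to the oxygen link or depends on chain length, which a shorter propyloxy or methoxy group would test. A longer chain such as octylamino, or a plain amino group at this position, could show how far the flat reading among the amino compounds extends.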